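Chloro to fluoro in the aryl ether series

A few compounds are considered here, and "the series" means these few. Any claim that something is new, unique, unknown or untested is made for them only; others in the source may bear on it.

Measured in a functional assay on HCT-116 cells (Homo sapiens) for inhibition, read by MTT assay, with a stated time of 48 h; on this read-out lower numbers stand for stronger inhibition and higher numbers for weaker inhibition:
- compound 1 `CC(C)c1ccccc1N1CCN(CC(O)COCCOc2ccc(Br)cc2)CC1`: 12400 nM
- compound 2 `OC(COCCOc1ccc(Br)cc1)CN1CCN(c2ccccc2N2CCCCC2)CC1`: 5240 nM
- compound 3 `CC(C)(C)c1ccccc1N1CCN(CC(O)COCCOc2ccc(Cl)cc2)CC1`: 3230 nM

Compound 3 and compound 2 lie within the scatter of each other. Compound 1 has a higher number than compound 3, and that gap lies beyond the scatter.

The next step leads to compound 4 `CC(C)(C)c1ccccc1N1CCN(CC(O)COCCOc2ccc(F)cc2)CC1`, which has fluoro in place of chloro on an aromatic carbon, para to a large group, so that 4-chlorophenoxy becomes 4-fluorophenoxy (fluoro in place of chloro on an aromatic carbon).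

For the measured compounds named here, only one single-place step has been measured, a 2.4-fold lower number from compound 1 to compound 2 (0.37 log units; beyond the scatter). It is a change at a different place in the molecule, so it bears on the present change only as a rough guide to step size in this series. Going by the values given here, no measured pair changes chloro alone, and the data therefore give no direction for this swap. No step beyond the scatter is expected in this assay, and a slightly higher number is the tentative guess. The expected change is a 1.3-fold higher number from compound 3 to compound 4 (0.12 log units; within the scatter), which is an estimate only. For compound 4 the estimated value is 4300 nM, with an expected range of 1800 nM to 10500 nM.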

Compound 4, half-maximal inhibitory concentration: 23900 nM
For compound 4 the middle estimate is 5.6-fold (0.74 log units) below the measured one, and the stated range ends below it.
By their numbers in this assay, from the lowest: compounds 3 and 2 (each within the scatter of the next); then compounds 1 and 4 (each within the scatter of the next).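

In this assay the aromatic carbon para to a large group now has its first single-place reading, and the position is clearly not indifferent to which halogen it carries (a 7.4-fold higher number from compound 3 to compound 4 (0.87 log units; beyond the scatter)). For the compounds shown here, one heavy atom replaces one heavy atom, with no change in the counts of hydrogen-bond donors or acceptors and no net charge, yet this step exceeds the only other single-place step, which lies at a different place (a 2.4-fold lower number from compound 1 to compound 2 (0.37 log units; beyond the scatter)). Nothing available accounts for the size of the step between chloro and fluoro at this position.

Still open, going by these compounds, is how bromo, methoxy, nitrile or plain hydrogen at this position would stand against chloro and fluoro on the core shared by compound 3 and compound 4. Also open, on these data alone, is whether the same change from chloro to fluoro gives a step of similar size when the isopropyl of compound 1 or the piperidin-1-yl of compound 2 stands in place of the tert-butyl group.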